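The compounds below may be only part of what the source reports. "The series", "measured", "known", "first", "only" and "open" are said of these compounds alone.

Working notes on the series, all read in a functional assay on COLO 205 cells (Homo sapiens) for inhibition, read by sulforhodamine B assay, with a stated time of 48 h, tested at 50 uM; on this read-out higher numbers stand for more inhibition of growth at the one concentration tested and lower numbers for less inhibition of growth. Compound 1 `COc1cc(/C=C/C(=O)/C=C/c2cccs2)ccc1OCc1cn(CCOc2cc(=O)oc3ccccc23)nn1` gives 66%. Compound 2 `COc1ccccc1/C=C/C(=O)/C=C/c1ccc(OCc2cn(CCCOc3cc(=O)oc4ccccc34)nn2)c(OC)c1` gives 57%, which places it with compound 1 at the upper end of the three numbers, the two being within the scatter of each other. Compound 3 `COc1ccccc1/C=C/C(=O)/C=C/c1ccc(OCc2cn(CCCCCOc3cc(=O)oc4ccccc34)nn2)c(OC)c1` gives 30%, and the gap separating it from compound 2 is beyond the scatter.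

The next compound is compound 4 `COc1cc(/C=C/C(=O)/C=C/c2cc(OC)c(OC)c(OC)c2)ccc1OCc1cn(CCCOc2cc(=O)oc3ccccc23)nn1`, not yet measured. The change from compound 2 is 3,4,5-trimethoxyphenyl in place of 2-methoxyphenyl on a double-bonded chain carbon bound to a double-bonded chain carbon. Among the compounds with values here, no measured pair isolates this change, so the data give no direct size for it, and no clear direction can be argued. No shift beyond the scatter is expected. The estimated move is a number 2 percentage points lower from compound 2 to compound 4 (within the scatter). For compound 4 the expected value is 55%, with an estimated range of 35% to 75%.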

Compound 4, percent growth inhibition at one concentration: 74%
Beside the measured number, compound 4's estimate is 19 percentage points below it, within the range that was stated.
By their numbers in this assay, from the lowest: compound 3; then compounds 2, 1 and 4 (each within the scatter of the next, the first and the last beyond it).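

In this assay, within the data shown here, 3,4,5-trimethoxyphenyl in place of 2-methoxyphenyl on a double-bonded chain carbon bound to a double-bonded chain carbon gives a number 17 percentage points higher from compound 2 to compound 4 (beyond the scatter) and thus the first size for any change at this position. With the rest of the structure held fixed, the group at this position affects the growth inhibition read-out, and the larger group, with 12 heavy atoms against 8, does not lower it. Nothing measured in hand accounts for this step.

Going by these compounds, it stays open whether all the methoxy groups of the 3,4,5-trimethoxyphenyl are needed for the step, and how an aminophenyl or a carboxyphenyl group would read at this position. On these data alone, it is equally open whether the step holds with a longer chain in the linker.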